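Benzylamine sulfonamides: swapping the aryl group

A few compounds are considered here, and "the series" means these few. Any claim that something is new, unique, unknown or untested is made for them only; others in the source may bear on it.

Measured compounds:
compound 1 `CC(C)(C)c1ccc(CNCCCNS(=O)(=O)c2cc(C(F)(F)F)cc(C(F)(F)F)c2)cc1`: 2100 nM
compound 2 `COc1ccccc1CNCCCNS(=O)(=O)c1cc(C(F)(F)F)cc(C(F)(F)F)c1`: 2600 nM

In a functional assay on MCF7 cells (Homo sapiens) for inhibition, read by MTT assay, with a stated time of 72 h (on this read-out higher numbers stand for weaker inhibition of growth and lower numbers for stronger inhibition of growth), compound 1 gives 2100 nM, and compound 2 gives 2600 nM. Compound 2 therefore holds the highest of the two numbers recorded, yet its nearest neighbour, compound 1, lies within the scatter of it, so no order between the two can be claimed. Among the measured compounds shown here, the single measured step, a 1.2-fold higher number from compound 1 to compound 2 (0.09 log units; within the scatter), shows that exchanging one aryl group for another on the saturated chain carbon bound to the amine nitrogen left the growth inhibition essentially unchanged.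

Compound 3 `O=S(=O)(NCCCNCc1ccc(Cl)c(Cl)c1)c1cc(C(F)(F)F)cc(C(F)(F)F)c1` has not yet been measured. It differs from compound 2 by 3,4-dichlorophenyl in place of 2-methoxyphenyl on a saturated chain carbon bound to an amine nitrogen. For the measured compounds named here, the only step that bears on this change is the one from compound 1 to compound 2, which stayed within the scatter, and that step concerns the same position. On this basis compound 3 is expected to give a number close to that of compound 2 in this assay, with no step beyond the scatter expected, a 1.2-fold lower number from compound 2 to compound 3 (0.07 log units; within the scatter). The estimate for compound 3 is 2200 nM, with a range from 900 nM to 5500 nM.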

Compound 3, concentration for 50% growth inhibition: 2400 nM
For compound 3 the middle estimate is 1.1-fold (0.04 log units) below the measured one, and the stated range covers the measured number.
By their numbers in this assay, from the lowest: compounds 1, 3 and 2 (each within the scatter of the next).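

A third aryl group at this place, on a saturated chain carbon bound to an amine nitrogen, extends the picture in this assay: the result is a 1.1-fold lower number from compound 2 to compound 3 (0.03 log units; within the scatter), and alongside it stands a 1.1-fold higher number from compound 1 to compound 3 (0.06 log units; within the scatter), so all three compounds lie within the scatter of one another. The earlier pair offered a single step, whereas 4-(tert-butyl)phenyl, 2-methoxyphenyl and 3,4-dichlorophenyl now give numbers that do not separate, even though the exchange of 2-methoxyphenyl for 3,4-dichlorophenyl removes the oxygen and its hydrogen-bond acceptor and brings in two chlorine atoms at the same count of heavy atoms. Nothing on hand explains why these three groups read alike.

The compounds shown leave open whether the number would respond to something other than a substituted phenyl ring at this place, such as a cyclohexyl ring or a phenyl ring carrying a carboxylic acid, or to a longer chain in the shared core. On these data alone, the two trifluoromethyl groups stand in all three compounds, so their part in the read-out remains unknown.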